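The compounds below may be only part of what the source reports. "The series", "measured", "known", "first", "only" and "open" are said of these compounds alone.

Measured so far:

Compound 1, `COc1cccc(-c2cc3[nH]nc(N)c3c(=O)[nH]2)c1`, 17%
Compound 2, `COc1cccc(-c2cc3c(c(N)nn3C)c(=O)[nH]2)c1`, 25%
Compound 3, `Cc1cc2c(cn1)c(N)nn2C`, -3%

All three were tested in an assay on isolated protein for inhibition of serine/threonine-protein kinase D2 (Homo sapiens), read by mobility shift assay, tested at 30 uM; on this read-out lower numbers stand for less inhibition and higher numbers for more inhibition at the one concentration tested (going by the name of the read-out). Compounds 1 and 2 share one core, and in this assay compound 1 gives 17% while compound 2 gives 25%. The two differ in a single place: hydrogen in place of methyl on an aromatic nitrogen. This change gave a number 8 percentage points lower from compound 2 to compound 1 (within the scatter), so the two numbers cannot be told apart with confidence.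

Compound 3 has a different core; the difference between the two cores is not broken down here. In this assay compound 3 gives -3%, the lowest of the three numbers, and its gaps to compound 1 and to compound 2 both lie beyond the usual scatter.

The unmeasured compound 4, `Cc1cc2[nH]nc(N)c2cn1`, differs from compound 3 in one place: hydrogen in place of methyl on an aromatic nitrogen. Going by the values given here, this is the same change as the one from compound 2 to compound 1, and the surroundings of the place are described in the same words for both pairs. Among the compounds with values here, the only guide to its effect is therefore that earlier pair, where the change made a step within the scatter. Compound 4 is expected to stay close to compound 3, with an estimated step of a number 1 percentage points higher from compound 3 to compound 4 (within the scatter) because the same change gave a number 8 percentage points lower from compound 2 to compound 1 (within the scatter). In this assay compound 4 is estimated at -2%, most likely between -12% and 10%.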

Compound 4, a percentage reported as inhibition, at one concentration (the size of the read-out at that concentration, not a potency): 25%
For compound 4 the middle estimate is 27 percentage points below the measured one; the whole stated range lies below it.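

In this assay the swap of methyl for hydrogen on an aromatic nitrogen gave a number 28 percentage points higher from compound 3 to compound 4 (beyond the scatter) and so, on the smaller core, made a difference that the usual scatter does not account for. The same swap therefore did not carry over from one core to the other, and the step seen on one core was a poor guide to the step on the other: the same change on two cores in this assay, a number 8 percentage points lower (within the scatter) from compound 2 to compound 1 and a number 28 percentage points higher (beyond the scatter) from compound 3 to compound 4, 36 percentage points apart, beyond the scatter of two such steps. Going by these compounds alone, this does not show why the two cores respond differently, and with only two pairs it gives no rule for what the swap would do on a third core; the numbers also come from a single concentration, so they describe the size of inhibition at that concentration and not potency.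

The compounds shown have only hydrogen or methyl on this nitrogen, so it remains open how an ethyl group, a longer chain or a chain ending in an amine would behave there on either core. It also remains open which part of the larger core of compound 1 makes the swap behave differently, as no compounds shown separate the 3-methoxyphenyl group from the rest of that core.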